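The source may hold more compounds than are shown below. What is called first, only, known or untested is meant among the compounds shown, and "the series" means these compounds.

Compound 1 `O=C(Nc1ccc(-c2cscn2)cc1)C1CCCN(Cc2cccnc2)C1` gives only a limit in a functional assay on A-375 cells (Homo sapiens) for activation, with a stated time of 3 days (a lower number here means that less compound is needed, a higher number that more compound is needed for the effect), > 20000 nM, so no number stands for it; this is the limit of > 20000 nM in this assay, at which 1 of the 2 values shown sits. Among the compounds with values here, compound 2 `O=C(Nc1ccc(-c2ccncc2)cc1)C1CCCN(Cc2ccc(F)c(F)c2)C1` gives 1180 nM in this assay, the one number in the set so far. Compound 3 `O=C(Nc1ccc(-c2ccc[nH]2)cc1)C1CCCN(Cc2ccc(F)c(F)c2)C1` carries 1H-pyrrol-2-yl in place of pyridin-4-yl on an aromatic carbon. Within the data shown here, no step between measured compounds is available, so the size of such a change is untested here. A loss of potency beyond the scatter is expected in this assay, the estimated step being a 4.2-fold higher number from compound 2 to compound 3 (0.63 log units; beyond the scatter). For compound 3 the estimated value is 5000 nM, with a range from 1500 nM to 20000 nM.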

Compound 3, half-maximal effective concentration: 720 nM
Beside the measured number, compound 3's estimate is 6.9-fold (0.84 log units) above it; the measured number lies below the stated range.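

In this assay the exchange on this aromatic carbon, para to a large group, gives a 1.6-fold lower number from compound 2 to compound 3 (0.21 log units; within the scatter) and so shows that this position accepts 1H-pyrrol-2-yl in place of pyridin-4-yl with no change beyond the scatter. The position therefore tolerates a five-membered aromatic ring carrying a hydrogen-bond donor as well as a six-membered one carrying a hydrogen-bond acceptor. No measurement shown gives a reason for this.

From the compounds shown here alone, how a plain phenyl ring, an aminomethyl group or a carboxylic acid would read on this carbon stays open.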